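Adding one methyl to the ethyl chain of compound 3

The source may hold more compounds than are shown below. What is called first, only, known or untested is meant among the compounds shown, and "the series" means these compounds.

Compound 1 `CCOC(=O)c1ccc(-c2nn(Cc3ccc(Cl)cc3)c3ccccc23)cc1` gives 120 nM
Compound 2 `CCOC(=O)c1ccc(-c2nn(Cc3ccccc3OC)c3ccccc23)cc1` gives 470 nM
Compound 3 `CCOC(=O)c1ccc(-c2nn(CC)c3ccccc23)cc1` gives 360 nM

These numbers come from a functional assay on cells (Platelet, Homo sapiens) for inhibition (a lower number here means a stronger inhibitor, a higher number a weaker inhibitor), and the three compounds differ only in what sits on a saturated chain carbon bound to an aromatic nitrogen. Compound 3 carries an ethyl group at that spot. Its nearest neighbour on the scale shows a 1.3-fold lower number from compound 2 to compound 3 (0.12 log units; within the scatter) so those two cannot be separated. Compound 1 is the strongest inhibitor of the three, with a 3.0-fold higher number from compound 1 to compound 3 (0.48 log units; beyond the scatter) and also a 3.9-fold higher number from compound 1 to compound 2 (0.59 log units; beyond the scatter) in its other comparison.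

Compound 4 `CCOC(=O)c1ccc(-c2nn(C(C)C)c3ccccc23)cc1` turns the ethyl into isopropyl, and the change counts as methyl in place of hydrogen on a saturated chain carbon bound to an aromatic nitrogen and a saturated chain carbon in full. For the measured compounds named here, the measured steps at this same chain carbon are the only guide, and none of them adds a single methyl in this way. They exchange 4-chlorophenyl or 2-methoxyphenyl for methyl, and even those replacements gave only a modest step or one within the scatter. The estimated step is a 1.2-fold lower number from compound 3 to compound 4 (0.08 log units; within the scatter) so no shift beyond the scatter is expected in this assay in either direction. Compound 4 is expected at 300 nM with an estimated range of 130 nM to 650 nM in this measurement.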

Compound 4, half-maximal inhibitory concentration: 650 nM
The estimate for compound 4 lay 2.2-fold (0.34 log units) below the measured number, within the range that was stated.
By their numbers in this assay, from the lowest: compound 1; then compounds 3, 2 and 4 (each within the scatter of the next).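

In this assay, for the compounds shown here, this is the first step that adds a single methyl at this chain carbon, and turning ethyl into isopropyl gives no shift that can be told apart from repeat-measurement noise (a 1.8-fold higher number from compound 3 to compound 4 (0.26 log units; within the scatter)). Compound 4 also cannot be separated from the 2-methoxybenzyl compound (a 1.4-fold higher number from compound 2 to compound 4 (0.14 log units; within the scatter)), whereas the 4-chlorobenzyl group on the aromatic nitrogen keeps compound 1 the strongest inhibitor of the four (a 5.4-fold higher number from compound 1 to compound 4 (0.73 log units; beyond the scatter)). Among these four compounds, then, ethyl, isopropyl and 2-methoxybenzyl form one group at this nitrogen, and only 4-chlorobenzyl stands apart from compound 4, although the benzyl pair shows that a benzyl group alone does not guarantee the stronger result.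

Nothing available here accounts for these differences. As far as these compounds go, it stays open whether a plain benzyl group, a 4-methoxybenzyl group, a cyclopropyl ring, a longer chain such as butyl, or a chain ending in an amine would sit with compound 1 or with the other three.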